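An Ester in Place of the Acid on the Shared Core

The source may report more compounds than this note shows. Statements on the series, on what has been measured and on what is new or still open speak of the compounds shown alone.

Measured so far in an assay on HL-60 cells for agonist activity at vitamin D3 receptor (Homo sapiens), read by microscopy, with a stated time of 96 h; a higher number here means that more compound is needed for the effect, a lower number that less compound is needed:
Compound 1 `CCOC(=O)CN(C)C(=O)c1ccc(C(CC)(CC)c2ccc(OCC(O)C(C)(C)C)c(C)c2)n1CC`, giving 210 nM
Compound 2 `CCn1c(C(=O)N(CCC#N)CCC#N)ccc1C(CC)(CC)c1ccc(OCC(O)C(C)(C)C)c(C)c1`, giving 97 nM
Compound 3 `CCn1c(C(=O)N(C)CC(=O)O)ccc1C(CC)(CC)c1ccc(OCC(O)C(C)(C)C)c(C)c1`, giving 740 nM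

Compound 3 holds the highest number of the three; the nearest is compound 1 with 210 nM, the furthest compound 2 with 97 nM. Compound 4 `CCn1c(C(=O)OCc2ccc(F)cc2)ccc1C(CC)(CC)c1ccc(OCC(O)C(C)(C)C)c(C)c1` differs from compound 3 by (4-fluorobenzyl)oxy in place of (carboxymethyl)(methyl)amino on a carbonyl carbon. Going by the values given here, two measured steps bear on this. Going from an ethyl ester to the free acid raised the number, a 3.5-fold higher number from compound 1 to compound 3 (0.55 log units; beyond the scatter), while an amide without acid stood far lower, a 7.6-fold higher number from compound 2 to compound 3 (0.88 log units; beyond the scatter). Compound 4 removes the acid and reinstates an ester, so a lower number is expected, roughly undoing the earlier rise; the estimated step is a 4.6-fold lower number from compound 3 to compound 4 (0.67 log units; beyond the scatter). Compound 4 is therefore expected to give about 160 nM, between 50 nM and 500 nM.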

Compound 4, half-maximal effective concentration: > 50000 nM
Compound 4: no number, only a limit; the forecaster's own chance of this, stated with the estimate: 5%; at least 310-fold (2.49 log units) between middle value and limit.
By their numbers in this assay, from the lowest: compound 2; then compound 1; then compound 3. At a limit, above all of these: compound 4.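

On this carbonyl carbon, (4-fluorobenzyl)oxy in place of the earlier groups produces much larger steps in this assay than any seen before: an at least 67-fold higher number from compound 3 to compound 4 (1.82 log units; beyond the scatter), an at least 230-fold higher number from compound 1 to compound 4 (2.37 log units; beyond the scatter) and an at least 510-fold higher number from compound 2 to compound 4 (2.71 log units; beyond the scatter). All three compounds with a measured number carry an amino group here, whereas compound 4 has an oxygen, so removing the acid does not by itself restore a low number. The result for compound 4 is a limit, not a number: the limit of > 50000 nM in this assay, at which 1 of the 4 values shown sits.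

As far as these compounds go, whether the oxygen link or the 4-fluorobenzyl part goes with this loss remains open. A 4-fluorobenzylamino or a methoxy group on this carbonyl carbon would separate the two.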